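A Third Methoxy Group Added to Compound 3

This account rests on a few compounds, and the source may have more. Where it says the series, first, only, none or still open, it means among the compounds named here.

The three compounds are compared in a functional assay on DU-145 cells (Homo sapiens) for antiproliferative activity, with a stated time of 48 h; on this read-out higher numbers stand for lower toxicity in this test and lower numbers for higher toxicity in this test. Compound 1 `Cc1cc(O)c(C2=NN(c3ccc(S(N)(=O)=O)cc3)C(c3ccccc3O)C2)cc1Cl` gives 10600 nM in this assay. Compound 2 `Cc1cc(O)c(C2=NN(c3ccc(S(N)(=O)=O)cc3)C(/C=C/c3ccccc3)C2)cc1Cl` returns only a limit of this assay, > 100000 nM. Compound 3 `COc1ccc(C2CC(c3cc(Cl)c(C)cc3O)=NN2c2ccc(S(N)(=O)=O)cc2)cc1OC` likewise returns only a limit, > 100000 nM. That boundary is the limit of > 100000 nM in this assay, at which 2 of the 3 values shown sit. Compound 3 thus stands at the upper edge of the numbers shown, together with compound 2, while compound 1 alone gives a readable number. The two steps away from compound 1 are an at least 9.4-fold higher number from compound 1 to compound 2 (0.97 log units; beyond the scatter) and an at least 9.4-fold higher number from compound 1 to compound 3 (0.97 log units; beyond the scatter); the remaining pair gives a step that the two limits leave unreadable from compound 2 to compound 3.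

Compound 4 `COc1ccc(C2CC(c3cc(Cl)c(C)cc3O)=NN2c2ccc(S(N)(=O)=O)cc2)c(OC)c1OC` differs from compound 3 by methoxy in place of hydrogen on an aromatic carbon. Within the data shown here, no measured step concerns the addition of a methoxy group: the two measured steps that end at a limit both concern the replacement of 2-hydroxyphenyl by another group, and compound 3 already sits at that limit, so a further methoxy group on the 3,4-dimethoxyphenyl group has no directly readable reference. Compound 4 is expected to stay at the limit, which corresponds to a step of a number no higher from compound 3 to compound 4 (the limit leaves the size open). The estimate for compound 4 is accordingly 100000 nM, within a range from 30000 nM to 300000 nM.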

Compound 4, concentration lethal to 50% of the cells: 54900 nM
Compound 4: middle estimate off by 1.8-fold (0.26 log units), on the high side, within the range that was stated.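

On these data alone, compound 4 comes off the boundary in this assay and gives a readable number, which compound 2 and compound 3 do not: the limit of > 100000 nM in this assay, at which 2 of the 4 values shown sit. The methoxy group added to the 3,4-dimethoxyphenyl group gives an at least 1.8-fold lower number from compound 3 to compound 4 (0.26 log units; that floor lies within the scatter), and the change on the saturated ring carbon from 2-phenylethenyl gives an at least 1.8-fold lower number from compound 2 to compound 4 (0.26 log units; that floor lies within the scatter); each is only a floor, so neither shows on its own that the number really moved, and the true size of both remains unknown. What is new is a full measured size for leaving the 2-hydroxyphenyl group, with the 2,3,4-trimethoxyphenyl group in its place: the earlier replacements gave only limits, whereas this one gives a 5.2-fold higher number from compound 1 to compound 4 (0.71 log units; beyond the scatter).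

The compounds shown leave open whether a single methoxy group on that phenyl ring, in the place of the hydroxy group of compound 1, would stay close to compound 1 or move towards compound 4. They also leave open where an amine or a carboxylic acid at that same place on the ring would fall in this test.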